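Moving the ring nitrogen in the aryl ether of compound 2

The source may hold more compounds than are shown below. What is called first, only, known or untested is meant among the compounds shown, and "the series" means these compounds.

Measured so far:
compound 1, `CC(C)CCn1ccc(-c2ccccc2)c(C#N)c1=O`, 8510 nM
compound 2, `CC(C)CCn1ccc(-c2ccc(Oc3ccccn3)cc2)c(C#N)c1=O`, 646 nM

Both compounds were tested in a functional assay on CHO cells for positive allosteric modulation of metabotropic glutamate receptor 2 (Homo sapiens), read by scintillation counting and GTPgammaS binding, with a stated time of 30 min; a lower number here means that less compound is needed, a higher number that more compound is needed for the effect. Compound 2 has the lowest number of the two, and its nearest neighbour is compound 1, which lies a 13-fold lower number from compound 1 to compound 2 (1.12 log units; beyond the scatter) away from it. Compound 3, `CC(C)CCn1ccc(-c2ccc(Oc3cccnc3)cc2)c(C#N)c1=O`, has not yet been measured. It differs from compound 2 only by pyridin-3-yl in place of pyridin-2-yl on an oxygen on an aromatic ring. For the measured compounds named here, no measured step shows what moving the ring nitrogen within the pyridyl group does; the only step recorded, a 13-fold lower number from compound 1 to compound 2 (1.12 log units; beyond the scatter), shows that the pyridyloxy group as a whole matters a great deal. With nothing else to go on, a modest loss for compound 3 is expected, giving a 1.7-fold higher number from compound 2 to compound 3 (0.23 log units; within the scatter). Compound 3 is therefore estimated at 1100 nM in this assay, within a range of 300 nM to 4000 nM.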

Compound 3, half-maximal effective concentration: 479 nM
Compound 3: the middle estimate sits 2.3-fold (0.36 log units) above what was measured; low and high end bracket the measured number.
By their numbers in this assay, from the lowest: compounds 3 and 2 (each within the scatter of the next); then compound 1.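

In this assay, moving the ring nitrogen of the aryl ether gives a 1.3-fold lower number from compound 2 to compound 3 (0.13 log units; within the scatter), so pyridin-3-yl and pyridin-2-yl on this oxygen cannot be told apart here. The large effect of replacing hydrogen on the aromatic carbon also appears with the second isomer, as an 18-fold lower number from compound 1 to compound 3 (1.25 log units; beyond the scatter) shows, so across these two compounds it does not depend on which of the two pyridyl groups is present. Nothing at hand explains this result.

Still open, as far as these compounds go, is whether phenyl or pyridin-4-yl on the same oxygen would give a similar number, and whether a methylene link could take the place of the oxygen. From the compounds shown here alone, the chain on the shared core is the same in all three compounds, so the effect of a shorter or longer chain there also remains open.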